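The source may report more compounds than this note shows. Statements on the series, on what has been measured and on what is new or still open speak of the compounds shown alone.

Compound 1 `CCCCNc1nnc(SCC(=O)N(Cc2cccc([N+](=O)[O-])c2)c2ccc(F)cc2)s1` — 40.6%
Compound 2 `CC(C)CNc1nnc(SCC(=O)N(Cc2cccc([N+](=O)[O-])c2)c2ccc(F)cc2)s1` — 36%
Compound 3 `COCCNc1nnc(SCC(=O)N(Cc2cccc([N+](=O)[O-])c2)c2ccc(F)cc2)s1` — 38.6%

In an assay on isolated protein for inhibition of Amine oxidase [flavin-containing] B (Homo sapiens), read by fluorescence and Amplex Red, with a stated time of 30 min, tested at 1 mM (on this read-out lower numbers stand for a weaker effect and higher numbers for a stronger effect at the one concentration tested), compound 1 holds the highest of the three numbers, yet both others lie within the scatter of it: a number 4.6 percentage points lower from compound 1 to compound 2 (within the scatter) and a number 2 percentage points lower from compound 1 to compound 3 (within the scatter), while between the other two a number 2.6 percentage points higher from compound 2 to compound 3 (within the scatter). Compound 4 `CCNc1nnc(SCC(=O)N(Cc2cccc([N+](=O)[O-])c2)c2ccc(F)cc2)s1` differs from compound 1 by hydrogen in place of ethyl on a saturated chain carbon, two bonds along the chain from a nitrogen on an aromatic ring. All three measured steps change the same chain on the shared core and none of them moved the read-out beyond the scatter, so the shortening in compound 4 is not expected to either. For compound 4 the expected step is a number 2.6 percentage points lower from compound 1 to compound 4 (within the scatter). Compound 4 is therefore estimated at 38%, within a range from 28% to 48%.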

Compound 4, a percentage reported as inhibition, at one concentration (the size of the read-out at that concentration, not a potency): 41.3%
Estimate against measurement, compound 4: 3.3 percentage points below; the range from low to high includes it.
By their numbers in this assay, from the lowest: compounds 2, 3, 1 and 4 (each within the scatter of the next).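

In this assay, cutting butylamino back to ethylamino leaves the read-out unmoved, with a number 0.7 percentage points higher from compound 1 to compound 4 (within the scatter). The shorter chain also stands level with the methoxy-bearing and branched chains, with a number 2.7 percentage points higher from compound 3 to compound 4 (within the scatter) and with a number 5.3 percentage points higher from compound 2 to compound 4 (within the scatter), so among these four compounds neither length, branching nor an oxygen in the chain separates the numbers. Nothing available explains this flatness. Going by these compounds, whether a terminal amine, a carboxylic acid or a much longer chain at this position would move the number remains open, as does the effect of a phenyl ring there.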